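Dropping the Aromatic Chlorine from a Thiosemicarbazone Series

This account rests on a few compounds, and the source may have more. Where it says the series, first, only, none or still open, it means among the compounds named here.

Measured compounds:
Compound 1, `CC1=CC[C@@H]([C@@](C)(O)CCCC(C)(C)NC(=S)N/N=C\c2ccc(C)cc2)CC1` — 7950 nM
Compound 2, `CC1=CC[C@@H]([C@@](C)(O)CCCC(C)(C)NC(=S)N/N=C\c2ccc(O)cc2)CC1` — 31100 nM
Compound 3, `CC1=CC[C@@H]([C@@](C)(O)CCCC(C)(C)NC(=S)N/N=C\c2ccc(Cl)cc2)CC1` — 730 nM

The three measured compounds share one core and differ only in the group on the aromatic ring of the hydrazone part. In a functional assay on K562 cells (Homo sapiens) for cytotoxicity, read by sulforhodamine B assay (a lower number here means a stronger inhibitor of growth, a higher number a weaker inhibitor of growth), compound 3 stands lowest of the three; the nearest is compound 1 with an 11-fold lower number from compound 1 to compound 3 (1.04 log units; beyond the scatter), and the furthest is compound 2 with a 43-fold lower number from compound 2 to compound 3 (1.63 log units; beyond the scatter). Between the other two, the step is a 3.9-fold higher number from compound 1 to compound 2 (0.59 log units; beyond the scatter).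

Compound 4, `CC1=CC[C@@H]([C@@](C)(O)CCCC(C)(C)NC(=S)N/N=C(/C)c2ccccc2)CC1`, has not yet been measured. It differs from compound 3 by a group of 9 heavy atoms (8 carbon, 1 nitrogen; one six-membered aromatic ring of carbon only) in place of a group of 9 heavy atoms (7 carbon, 1 nitrogen, 1 chlorine; one six-membered aromatic ring of carbon only), on an amide-type nitrogen. Within the data shown here, no measured step covers this change directly: every step so far swaps one group on the aromatic ring for another, whereas here the chlorine of compound 3 is lost and a methyl-bearing imine enters. Among the measured compounds shown here, what the measured steps do show is that compound 3, the only chloro compound, sits far below compound 1 and compound 2, by large margins in both cases. Losing the chloro is therefore expected to move compound 4 back toward the higher numbers, a step of roughly an 11-fold higher number from compound 3 to compound 4 (1.04 log units; beyond the scatter). The estimate for compound 4 in this assay is 8000 nM, with a range from 2000 nM to 32000 nM.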

Compound 4, concentration for total growth inhibition: 70 nM
Beside the measured number, compound 4's estimate is 110-fold (2.06 log units) above it; the measured number lies below the stated range.
By their numbers in this assay, from the lowest: compound 4; then compound 3; then compound 1; then compound 2.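

Compound 4 shows that a chloro group on the aromatic ring is not needed for a low number in this assay: with the chlorine lost and a methyl-bearing imine entering on the amide-type nitrogen, the series moves further down, with a 10-fold lower number from compound 3 to compound 4 (1.02 log units; beyond the scatter). The groups that differ between compound 1 and compound 4 have the same count, 9 heavy atoms (8 carbon, 1 nitrogen), so a different arrangement of those atoms alone gives a 110-fold lower number from compound 1 to compound 4 (2.06 log units; beyond the scatter), while the gap to the hydroxy compound widens to a 440-fold lower number from compound 2 to compound 4 (2.65 log units; beyond the scatter). The data shown offer no measurement that explains these steps.

What remains open is how much of the drop belongs to the methyl on the imine and how much to the ring carrying no further group, as the compounds shown change both together. Going by these compounds, it is also open whether the chloro group and the methyl-bearing imine would add up in one compound, and whether an ethyl group in place of that methyl would keep the number this low.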